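Phenyl to benzyloxy: the next step in the series

A few compounds are considered here, and "the series" means these few. Any claim that something is new, unique, unknown or untested is made for them only; others in the source may bear on it.

In a functional assay on MCF7 cells (Homo sapiens) for antiproliferative activity, read by MTT assay, with a stated time of 48 h (a lower number here means a stronger inhibitor, a higher number a weaker inhibitor), compound 1 (`N=C(N)N/N=C(/C=C/c1ccc(Br)cc1)c1ccccc1`) gives 250 nM, compound 2 (`N=C(N)N/N=C(/C=C/c1ccccc1)c1ccccc1`) gives 17000 nM and compound 3 (`N=C(N)N/N=C(/C=C/c1ccc(-c2ccccc2)cc1)c1ccccc1`) gives 800 nM. Compound 3 thus holds the middle place of the three numbers. Compound 4 (`N=C(N)N/N=C(/C=C/c1ccc(OCc2ccccc2)cc1)c1ccccc1`) has benzyloxy in place of phenyl on an aromatic carbon. Replacing hydrogen gave large steps: a 21-fold lower number from compound 2 to compound 3 (1.33 log units; beyond the scatter) for phenyl, and bromo differs by a 68-fold higher number from compound 1 to compound 2 (1.83 log units; beyond the scatter) in the reverse sense. Exchanging one large group for another gave only a 3.2-fold higher number from compound 1 to compound 3 (0.51 log units; beyond the scatter). The change at hand is of this second kind, so a small step in this assay is expected, with no firm direction. The estimated step is a 1.3-fold higher number from compound 3 to compound 4 (0.10 log units; within the scatter). For compound 4 the expected value is 1000 nM, with an estimated range of 250 nM to 4000 nM.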

Compound 4, half-maximal inhibitory concentration: 1200 nM
The estimate for compound 4 lay 1.2-fold (0.08 log units) below the measured number; low and high end bracket the measured number.
By their numbers in this assay, from the lowest: compound 1; then compounds 3 and 4 (each within the scatter of the next); then compound 2.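

At this position, benzyloxy and phenyl cannot be told apart in this assay (a 1.5-fold higher number from compound 3 to compound 4 (0.18 log units; within the scatter)), so the added oxygen-bearing link changes the number by no more than the scatter. Benzyloxy keeps a large gain over hydrogen (a 14-fold lower number from compound 2 to compound 4 (1.15 log units; beyond the scatter)) but, like phenyl, does not reach the level of bromo (a 4.8-fold higher number from compound 1 to compound 4 (0.68 log units; beyond the scatter)). No measurement at hand explains these differences. From the compounds shown here alone, whether an amine or a carboxylic acid at the same position would hold this level remains open, as does the effect of a longer chain ending in the same aromatic ring.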